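The compounds below may be only part of what the source reports. "The series", "measured", "known", "first", "only" and "open" are said of these compounds alone.

Compound 1 `CCC1(Cc2ccccc2)OS(=O)(=O)C=C1OCc1ccc(OC)cc1` is one of three close relatives tested in an ADME assay on HEL cells (Homo sapiens) for cytotoxicity, with a stated time of 3 days; a higher number here means that more compound is tolerated, a lower number that less compound is tolerated. In this assay compound 1 gives >= 200000 nM, which is a limit of the measurement rather than a number. Compound 2 `CC(C)CC1(Cc2ccccc2)OS(=O)(=O)C=C1OCc1ccccc1` carries a different group on a saturated ring carbon of the shared core. In this assay compound 2 gives >= 80000 nM, again a limit. Compound 3 `CC(C)C1(Cc2ccccc2)OS(=O)(=O)C=C1OCc1ccccc1` differs from compound 2 by an isopropyl in place of an isobutyl on a saturated ring carbon. In this assay compound 3 gives >= 80000 nM, also a limit. The step that the two limits leave unreadable from compound 2 to compound 3 can therefore not be read. Where compound 1 stands is known only as a bound: the limit of >= 200000 nM in this assay, at which 1 of the 3 values shown sits, while (the limit of >= 80000 nM in this assay, at which 2 of the 3 values shown sit).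

Compound 4 `CCC1(Cc2ccccc2)OS(=O)(=O)C=C1OCCCc1ccccc1` differs from compound 1 by phenethyl in place of 4-methoxyphenyl on a saturated chain carbon bound to an oxygen on an unsaturated carbon. Within the data shown here, no measured step bears directly on this change, and the one step that exists, a step that the two limits leave unreadable from compound 2 to compound 3, is itself unreadable. Every value shown sits at a limit, so no direction of change can be drawn for this assay. The step of an at least 1.3-fold lower number from compound 1 to compound 4 (0.12 log units; that floor lies within the scatter) is expected to stay within the usual scatter. The estimate for compound 4 in this assay is 150000 nM, ranging from 50000 nM to 300000 nM, and most likely only a limit will again be reported.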

Compound 4, minimum cytotoxic concentration: >= 20000 nM
Compound 4 ended at the assay's limit; the forecaster's own chance of this, stated with the estimate: 70%; the middle value does not contradict the limit.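

In this assay compound 1 and compound 4 both give only limits of the measurement, not numbers, so the step between them, phenethyl in place of 4-methoxyphenyl, cannot be read. With every value shown being a limit, the compounds shown leave open whether any change on the shared core alters the tolerated concentration at all.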